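Compound 3: a new group on the saturated ring

A few compounds are considered here, and "the series" means these few. Any claim that something is new, unique, unknown or untested is made for them only; others in the source may bear on it.

Compound 1 `COc1ccc(-c2c(C)nc3c(N4CC[C@@H](NS(=O)(=O)c5ccc(Cl)cc5)C4)cc(C)nn23)cc1OC`: > 95%
Compound 2 `COc1ccc(-c2c(C)nc3c(N4CC[C@@H](NS(=O)(=O)c5ccc(C#N)cc5)C4)cc(C)nn23)cc1OC`: > 95%

In an ADME assay on microsomes from liver (Homo sapiens) for metabolic stability, read by LC-MS, with NADPH named in the record, with a stated time of 60 min, tested at 1 uM, in the absence of a further agent (a lower number here means that less of the compound is left, a higher number that more of the compound is left), compound 2 gives > 95%, which is a limit and not a number. Compound 3 `COc1ccc(-c2c(C)nc3c(N4CC[C@@H](n5cc(-c6ccccc6)nn5)C4)cc(C)nn23)cc1OC` changes one group of compound 2: 4-phenyl-1H-1,2,3-triazol-1-yl in place of ((4-cyanophenyl)sulfonyl)amino on a saturated ring carbon. In short, 4-phenyl-1H-1,2,3-triazol-1-yl comes in place of ((4-cyanophenyl)sulfonyl)amino on a saturated ring carbon. Among the measured compounds shown here, the one measured step, a step that the two limits leave unreadable from compound 1 to compound 2, offers no size to carry over because of the limit of > 95% in this assay, at which 2 of the 2 values shown sit. It also lies on an aromatic carbon, not at this place. Compound 2 at > 95% leaves room mainly downward, so a fall is expected. The expected change is a number at least 15 percentage points lower from compound 2 to compound 3 (beyond the scatter). For compound 3 the estimate is 80%, with an expected range from 55% to 98%.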

Compound 3, percent of the compound remaining: "unstable" (no number reported)
For compound 3 the study gives words and no number; no gap can be computed for the estimate.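

Among the compounds shown here, compound 3 is described only in words, as unstable, without a number, so no step from compound 2 to compound 3 can be read. The compounds shown leave open how much of compound 3 remains.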